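This account rests on a few compounds, and the source may have more. Where it says the series, first, only, none or still open, it means among the compounds named here.

Working notes on the series, read in a functional assay on Huh-5-2 cells (Homo sapiens) for cytotoxicity, read by microscopy; on this read-out lower numbers stand for higher toxicity in this test and higher numbers for lower toxicity in this test. Compound 1 (`CC(=O)OC[C@H]1O[C@@H](n2c(SCc3cc4ccccc4oc3=O)nc3cncnc32)[C@H](OC(C)=O)[C@@H]1OC(C)=O`) gives 39000 nM and compound 2 (`CC(=O)OC[C@H]1O[C@@H](n2c(SCc3cc4ccccc4oc3=O)nc3cncnc32)[C@H](O)[C@@H]1O`) gives 8700 nM in this read-out. Compound 3 (`O=c1oc2ccccc2cc1CSc1nc2cncnc2n1[C@@H]1O[C@H](CO)[C@@H](O)[C@H]1O`) gives 50000 nM and so lies within the scatter of compound 1, with compound 2 well apart from both.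

Compound 4 (`O=c1oc2ccc(Cl)cc2cc1CSc1nc2cncnc2n1[C@@H]1O[C@H](CO)[C@@H](O)[C@H]1O`) departs from compound 3 by one change: chloro in place of hydrogen on an aromatic carbon with chloro in place of hydrogen on an aromatic carbon. Among the measured compounds shown here, the only measured step between compounds differing in one place is a 5.7-fold higher number from compound 2 to compound 3 (0.76 log units; beyond the scatter) for hydrogen in place of acetyl on an oxygen on a saturated carbon. That is a different kind of site, so this step serves only as a rough yardstick of size. For the measured compounds named here, no measured compound carries a substituent on this aromatic ring, so the direction is a weakly held guess. A modest move toward a lower number is expected, smaller than that yardstick.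

The estimated change is a 1.7-fold lower number from compound 3 to compound 4 (0.22 log units; within the scatter) in this assay as the expected outcome. For compound 4 the estimated value is 30000 nM with an expected range from 10000 nM to 70000 nM in this read-out.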

Compound 4, half-maximal cytotoxic concentration: 37000 nM
For compound 4 the middle estimate is 1.2-fold (0.09 log units) below the measured one; low and high end bracket the measured number.
By their numbers in this assay, from the lowest: compound 2; then compounds 4, 1 and 3 (each within the scatter of the next).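

In this assay chloro in place of hydrogen on this aromatic carbon gives a 1.4-fold lower number from compound 3 to compound 4 (0.13 log units; within the scatter) and so cannot be told apart from hydrogen here. Among the compounds shown here, this is the first reading on the six-membered aromatic ring of carbon only, since the earlier step, a 5.7-fold higher number from compound 2 to compound 3 (0.76 log units; beyond the scatter), concerned acetyl on an oxygen on a saturated carbon. Nothing at hand accounts for the result.

Open, from the compounds shown here alone, is whether a group other than chloro, such as methoxy, an amine or a carboxylic acid, would also stay within the scatter of hydrogen at this carbon, and whether chloro on the other carbons of this ring would do the same. Also open, going by these compounds, is whether chloro behaves alike in the acetyl-bearing compound 1 and compound 2, which carry hydrogen on this ring.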